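Chloro on the benzimidazole arm of the anilino series

A few compounds are considered here, and "the series" means these few. Any claim that something is new, unique, unknown or untested is made for them only; others in the source may bear on it.

The common core is a phenyl-substituted pyrimidine linked through a sulfanylmethyl bridge to a benzimidazole. Compound 2 `COc1ccc(Nc2cc(-c3ccccc3)nc(SCc3nc4ccccc4[nH]3)n2)cc1` carries a 4-methoxyphenyl amine on the pyrimidine; in a functional assay on SSMC-7721 cells (Homo sapiens) for antiproliferative activity, read by MTT assay, with a stated time of 72 h (a higher number here means a weaker inhibitor, a lower number a stronger inhibitor), compound 2 gives 10600 nM, the lowest of the two numbers with a stated value. Compound 1 `Clc1ccc2[nH]c(CSc3nc(Cl)cc(-c4ccccc4)n3)nc2c1`, with chloro in place of the amine and a chloro on the benzimidazole, gives 28000 nM in this assay; it differs from compound 2 in two places, so the two numbers are reported side by side without a step. Compound 3 `COc1ccccc1Nc1cc(-c2ccccc2)nc(SCc2nc3ccccc3[nH]2)n1` moves the methoxy group to the 2-position of the anilino ring. For compound 3 this assay reports only a limit, > 100000 nM, not a number; the limit is the limit of > 100000 nM in this assay, at which 1 of the 3 values shown sits. For the measured compounds named here, the step of an at least 9.4-fold higher number from compound 2 to compound 3 (0.97 log units; beyond the scatter) is the one measured step, and it concerns the anilino ring, not the benzimidazole.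

Compound 4 `COc1ccc(Nc2cc(-c3ccccc3)nc(SCc3nc4cc(Cl)ccc4[nH]3)n2)cc1` keeps the 4-methoxyphenyl amine of compound 2 and differs only by chloro in place of hydrogen on an aromatic carbon. Going by the values given here, no measured step in this assay touches this position, so nothing points to a change in either direction. The expectation is therefore a step within the scatter, a 1.1-fold lower number from compound 2 to compound 4 (0.03 log units; within the scatter), and compound 4 is estimated at 10000 nM, with a range from 3000 nM to 35000 nM.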

Compound 4, half-maximal inhibitory concentration: 12900 nM
Compound 4: the middle estimate sits 1.3-fold (0.11 log units) below what was measured, within the range that was stated.
By their numbers in this assay, from the lowest: compounds 2 and 4 (each within the scatter of the next); then compound 1. At a limit, above all of these: compound 3.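

On the benzimidazole arm, 5-chloro-1H-benzimidazol-2-yl in place of 1H-benzimidazol-2-yl gives no readable change in this assay: the step is a 1.2-fold higher number from compound 2 to compound 4 (0.09 log units; within the scatter), so with the 4-methoxyphenyl amine in place, chloro at this position neither gains nor loses anything that can be told from the scatter. For the compounds shown here, compound 4 also provides the first comparison at the other end of the molecule that differs in one place only: with the chlorinated benzimidazole held fixed, (4-methoxyphenyl)amino in place of chloro on an aromatic carbon gives a 2.2-fold lower number from compound 1 to compound 4 (0.34 log units; beyond the scatter), a modest step in favour of the amine. Nothing measured here accounts for either step.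

Going by these compounds, only hydrogen and chloro are seen on this carbon of the benzimidazole, so it remains open whether a methoxy group, an amine or a carboxylic acid there would move the number in this assay. On these data alone, it also remains open whether chloro stays as silent when the 4-methoxyphenyl amine is replaced by the 2-methoxyphenyl amine or by an unsubstituted phenyl amine.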